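A few compounds are considered here, and "the series" means these few. Any claim that something is new, unique, unknown or untested is made for them only; others in the source may bear on it.

In an ADME assay on microsomes from liver (Mus musculus) for metabolic stability, read by LC-MS, with a stated time of 10 min, tested at 0.5 uM (a lower number here means that less of the compound is left, a higher number that more of the compound is left), compound 2 (`c1ccc2c(c1)CN[C@@H](CN(CCC1CCNCC1)[C@H]1CCCc3cccnc31)C2`) gives 32% as the lower of the two numbers, and compound 1 (`c1ccc2c(c1)CN[C@H](CN(CCCN1CCNCC1)[C@H]1CCCc3cccnc31)C2`) has 88% left. The gap between these two compounds lies beyond the scatter. Compound 3 (`c1ccc2c(c1)CN[C@@H](CN(CCCN1CCN(C3CC3)CC1)[C@H]1CCCc3cccnc31)C2`) carries (4-cyclopropylpiperazin-1-yl)methyl in place of piperidin-4-yl on a saturated chain carbon, two bonds along the chain from an amine nitrogen. Within the data shown here, no measured step isolates this change. Compound 1 has a side chain closer to the entering group and stands at 88% here, so a rise is expected. The estimated move is a number 23 percentage points higher from compound 2 to compound 3 (beyond the scatter) in this assay and would lie beyond the scatter. For compound 3 the estimate is 55% with an expected range from 30% to 80% in this test.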

Compound 3, percent of the compound remaining: 3%
Compound 3: the middle estimate sits 52 percentage points above what was measured; measured number outside the range, below it.
By their numbers in this assay, from the lowest: compound 3; then compound 2; then compound 1.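

In this assay, putting (4-cyclopropylpiperazin-1-yl)methyl in place of piperidin-4-yl on a saturated chain carbon, two bonds along the chain from an amine nitrogen, gives a number 29 percentage points lower from compound 2 to compound 3 (beyond the scatter). Among these compounds, this is the first single-place step at this position, and it shows that the percent of compound remaining depends on the group carried there. Nothing available explains the drop. The step changes the whole side chain at once, so it does not separate the part played by the cyclopropyl from that of the piperazine. A methyl group in place of the cyclopropyl remains an open test.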